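The compounds below may be only part of what the source reports. "The series", "measured", "known", "first", "only" and "open" are said of these compounds alone.

Measured compounds in a functional assay (brain) for inhibition, with Rattus norvegicus as the target; on this read-out lower numbers stand for stronger inhibition and higher numbers for weaker inhibition:
- compound 1 `CC(=O)Oc1c(C)c(C)c2c(c1C)CCC(C)(C(=O)N1CCN(c3cc(N4CCCC4)nc(N4CCCC4)n3)CC1)O2`: 17000 nM
- compound 2 `CCNc1cccnc1N1CCN(C(=O)C2(C)CCc3c(C)c(O)c(C)c(C)c3O2)CC1`: 12000 nM
- compound 3 `CCN(CC)c1ccc(N2CCN(C(=O)C3(C)CCc4c(C)c(O)c(C)c(C)c4O3)CC2)nc1N(CC)CC`: 200 nM

Compound 2 holds the second highest number of the three. Its nearest neighbour is compound 1, whose number sits within the scatter of that of compound 2, so no order between these two can be stated. Compound 3 stands apart with a far lower number, beyond the scatter, and is the only one of the three at that level.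

Compound 4 `Cc1c(C)c2c(c(C)c1O)CCC(C)(C(=O)N1CCN(c3ncccn3)CC1)O2` has not yet been measured. It differs from compound 2 in one place: pyrimidin-2-yl in place of 3-(ethylamino)pyridin-2-yl on an amine nitrogen in a ring. Among the measured compounds shown here, no step between measured compounds touches this kind of change, so the direction has to be guessed. Compound 2 already shows a weak value with its 3-(ethylamino)pyridin-2-yl group, and compound 1, with a different substituted pyrimidine on the same ring nitrogen, gives a value in the same region; nothing here points to a move toward compound 3. The expected step of a 1.3-fold higher number from compound 2 to compound 4 (0.10 log units; within the scatter) is therefore small, within or near the scatter, with slightly weaker inhibition thought more likely than stronger. Compound 4 is estimated at 15000 nM, in a range from 4000 nM to 50000 nM.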

Compound 4, half-maximal inhibitory concentration: 23000 nM
Beside the measured number, compound 4's estimate is 1.5-fold (0.19 log units) below it, and the stated range covers the measured number.
By their numbers in this assay, from the lowest: compound 3; then compounds 2, 1 and 4 (each within the scatter of the next).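

In this assay, pyrimidin-2-yl in place of 3-(ethylamino)pyridin-2-yl on an amine nitrogen in a ring gives a 1.9-fold higher number from compound 2 to compound 4 (0.28 log units; within the scatter) so the two compounds cannot be ordered. Among the compounds shown here, this is the first one-place step at this position, and neither the 3 fewer heavy atoms nor the loss of the hydrogen-bond donor in the entering group comes with a step beyond the scatter. Nothing at hand bears on why the step is this small.

The compounds shown leave open whether a plain phenyl or a pyridin-2-yl without any substituent on the same ring nitrogen would stay within the scatter of compound 4. Also open, going by these compounds, is whether a single dimethylamino or a carboxylic acid on pyrimidin-2-yl would give a step beyond the scatter from compound 4.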